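Swapping an acid-bearing ring for a fluoro-nitro ring

This account rests on a few compounds, and the source may have more. Where it says the series, first, only, none or still open, it means among the compounds named here.

Three related compounds have been tested in a functional assay on DU-145 cells (Homo sapiens) for inhibition, read by trypan blue exclusion, with a stated time of 96 h; on this read-out lower numbers stand for stronger inhibition of growth and higher numbers for weaker inhibition of growth. Compound 1, `Cc1ccc(CS/C(=C/c2ccc(C(=O)O)cc2)C(=O)c2ccc(Cl)c([N+](=O)[O-])c2)cc1`, gives 10000 nM. Compound 3, `Cc1ccc(S/C(=C/c2ccc(O)c([N+](=O)[O-])c2)C(=O)c2ccc(Cl)cc2)cc1`, gives 10000 nM, a number level with that of compound 1 at the digits recorded, so the two sit together at the weak end of this small set. Compound 2, `COc1ccccc1/C=C(\C(=O)c1ccc(Br)cc1)S(=O)(=O)c1ccc(C)cc1`, gives 1000 nM, a lower number that lies beyond the usual scatter when set against compound 1, and so shows clearly stronger inhibition of growth.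

The next compound to be measured is compound 4, `Cc1ccc(CS/C(=C/c2ccc(F)c([N+](=O)[O-])c2)C(=O)c2ccc(Cl)c([N+](=O)[O-])c2)cc1`. It differs from compound 1 in a single place: 4-fluoro-3-nitrophenyl in place of 4-carboxyphenyl on a double-bonded chain carbon bound to a double-bonded chain carbon. Within the data shown here, no pair of measured compounds differs in only one place, so there is no directly comparable step to lean on. Among the measured compounds shown here, the only guide is that compound 1 and compound 3, which carry different groups on the ring in question, both return the same weak number. On that basis only a modest change is anticipated, if any beyond the scatter, with a slight lean toward a lower number. The expected value for compound 4 in this assay is 5000 nM, within a range from 1500 nM to 15000 nM. This estimate is expected to amount to a step of a 2.0-fold lower number from compound 1 to compound 4 (0.30 log units; within the scatter).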

Compound 4, concentration for 50% growth inhibition: 1000 nM
Compound 4: middle estimate off by 5.0-fold (0.70 log units), on the high side; measured number below the stated range.
By their numbers in this assay, from the lowest: compounds 2 and 4 (each within the scatter of the next); then compounds 1 and 3 (each within the scatter of the next).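

At this position, on a double-bonded chain carbon bound to a double-bonded chain carbon, the group matters in this assay: putting 4-fluoro-3-nitrophenyl in place of 4-carboxyphenyl gives a 10-fold lower number from compound 1 to compound 4 (1.00 log units; beyond the scatter). Among these compounds, this is the only pair here that differs in one place, so it gives the only direct reading of this position, and it shows that the 4-carboxyphenyl group is not needed for growth inhibition at this level. The swap changes several things together, since the entering group has 0 hydrogen-bond donors against 1 in the group that leaves and brings in nitrogen and fluorine, and no measurement here links the step to any one of these differences.

Going by these compounds, it remains open whether the gain comes from losing the carboxylic acid, from gaining the nitro group or the fluorine, or from some combination of these. Single-change partners on the same core, such as a plain phenyl ring, a 4-fluorophenyl or 3-nitrophenyl ring, or a methyl ester in place of the acid, would be needed to separate these possibilities.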